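A few compounds are considered here, and "the series" means these few. Any claim that something is new, unique, unknown or untested is made for them only; others in the source may bear on it.

Measured so far in a functional assay on M21 cells (Homo sapiens) for antiproliferative activity, read by sulforhodamine B assay, with a stated time of 48 h; on this read-out lower numbers stand for stronger inhibition and higher numbers for weaker inhibition:
- compound 1 `CCc1ccccc1NS(=O)(=O)c1ccc(N2CCNC2=O)cc1`: 180 nM
- compound 2 `Cc1ccc(NS(=O)(=O)c2ccc(N3CCNC3=O)cc2)c(C)c1`: 150 nM

Compound 2 stands level, within the scatter, with compound 1. Compound 3 `COc1cccc(NS(=O)(=O)c2ccc(N3CCNC3=O)cc2)c1` is still unmeasured. It carries 3-methoxyphenyl in place of 2,4-dimethylphenyl on a sulfonamide nitrogen. Going by the values given here, only one measured step bears on this change: a 1.2-fold lower number from compound 1 to compound 2 (0.08 log units; within the scatter), which lies within the scatter. That step exchanged 2-ethylphenyl for 2,4-dimethylphenyl, so it offers only weak guidance for 3-methoxyphenyl. A modest move towards weaker inhibition is expected, a 2.0-fold higher number from compound 2 to compound 3 (0.30 log units; within the scatter). For compound 3 the estimated value is 300 nM, with an expected range of 100 nM to 900 nM.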

Compound 3, half-maximal inhibitory concentration: 65 nM
Compound 3: the middle estimate sits 4.6-fold (0.66 log units) above what was measured; the measured number lies below the stated range.
By their numbers in this assay, from the lowest: compound 3; then compounds 2 and 1 (each within the scatter of the next).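

Changing the group on the sulfonamide nitrogen had moved nothing beyond the scatter until 3-methoxyphenyl entered, which gave in this assay a 2.3-fold lower number from compound 2 to compound 3 (0.36 log units; beyond the scatter) and a 2.8-fold lower number from compound 1 to compound 3 (0.44 log units; beyond the scatter). The site therefore does respond to the aryl group it carries, and the gain over 2,4-dimethylphenyl comes at an equal heavy-atom count, with one oxygen and one hydrogen-bond acceptor entering. Nothing available explains this shift. The compounds shown leave open whether the methoxy group itself matters, and whether an ethoxy group, a hydroxyl or an amine in its stead would hold the lower number.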